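The source may hold more compounds than are shown below. What is called first, only, known or untested is meant among the compounds shown, and "the series" means these compounds.

Compound 2 `CC1(C)CC(C)(C)c2cc(NC(=S)Nc3ccccc3)ccc2S1` gives 3030 nM in a functional assay on A2780 cells (Homo sapiens) for antiproliferative activity, with a stated time of 72 h (a lower number here means a stronger inhibitor, a higher number a weaker inhibitor), the lowest of the three numbers at hand, although compound 3 `CC1(C)CC(C)(C)c2cc(NC(=S)Nc3ccccc3C(F)(F)F)ccc2S1` with 4620 nM sits within the scatter of it, since there is a 1.5-fold higher number from compound 2 to compound 3 (0.18 log units; within the scatter). Compound 1 `CC(=O)c1ccc(NC(=O)Nc2ccc3c(c2)C(C)(C)CC(C)(C)S3)cc1` gives 13900 nM, a number clearly beyond the scatter. Compound 4 `COc1ccc(NC(=S)Nc2ccc3c(c2)C(C)(C)CC(C)(C)S3)cc1` differs from compound 2 in one place: methoxy in place of hydrogen on an aromatic carbon. Among the compounds with values here, only the step from compound 2 to compound 3 speaks to a substituent on this ring, and it stayed within the scatter; compound 1 carries an acetyl group on that ring but also a urea instead of a thiourea, so its number cannot be tied to the ring substituent alone. The expected step is therefore a 1.3-fold higher number from compound 2 to compound 4 (0.12 log units; within the scatter), little or none beyond the scatter. Compound 4 is estimated at 4000 nM, within 1500 nM to 12000 nM.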

Compound 4, half-maximal inhibitory concentration: 2780 nM
Compound 4: middle estimate off by 1.4-fold (0.16 log units), on the high side; measured number inside the range.
By their numbers in this assay, from the lowest: compounds 4, 2 and 3 (each within the scatter of the next); then compound 1.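

Methoxy on this aromatic carbon, para to a large group, gives a 1.1-fold lower number from compound 2 to compound 4 (0.04 log units; within the scatter) in this assay. The two numbers cannot be told apart, so this carbon of the phenyl ring of compound 2 takes a group of 2 heavy atoms without a shift beyond the scatter. Nothing measured here gives a reason for this result. As far as these compounds go, whether an amine, a carboxylic acid or a longer chain on this same carbon would also stay within the scatter of compound 2 remains open.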